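Urea to Amide Swap in a Weakly Inhibiting Series

This account rests on a few compounds, and the source may have more. Where it says the series, first, only, none or still open, it means among the compounds named here.

Measured compounds:
Compound 1 `COc1cc(-c2nn(-c3cccc(NC(=O)Nc4ccc(Cl)c(Cl)c4)c3)cc2-c2ccncc2)ccc1Cl`: 27600 nM
Compound 2 `O=C(Nc1cccc(-n2cc(-c3ccncc3)c(-c3ccc(Cl)c(O)c3)n2)c1)Nc1ccc(Cl)c(Cl)c1`: 16100 nM

Among the compounds with values here, in a functional assay on BT-549 cells (Homo sapiens) for inhibition, read by sulforhodamine B assay, with a stated time of 48 h (on this read-out higher numbers stand for weaker inhibition of growth and lower numbers for stronger inhibition of growth), compound 1 gives 27600 nM, the larger of the two numbers measured so far. Within the data shown here, its nearest neighbour, compound 2, gives 16100 nM in this assay, and the single measured step, a 1.7-fold lower number from compound 1 to compound 2 (0.23 log units; within the scatter), concerns only hydrogen in place of methyl on an oxygen on an aromatic ring.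

Compound 3 `COc1cc(-c2nn(-c3cccc(NC(=O)c4ccc(Cl)c(C(F)(F)F)c4)c3)cc2-c2ccncc2)ccc1Cl` differs from compound 1 by 4-chloro-3-(trifluoromethyl)phenyl in place of (3,4-dichlorophenyl)amino on a carbonyl carbon. Among the measured compounds shown here, no measured step bears on a change of this kind; the only step known sits elsewhere on the shared core and stayed within the scatter. The expectation for compound 3 therefore rests on compound 1 alone, with a wide range. Compound 3 is estimated at 20000 nM in this assay, within 5000 nM to 80000 nM. This estimate means a step of a 1.4-fold lower number from compound 1 to compound 3 (0.14 log units; within the scatter), expected to stay within the scatter in either direction.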

Compound 3, concentration for total growth inhibition: > 32500 nM
Compound 3 gave a limit, no number; the forecaster's own chance of this, stated with the estimate: 15%; middle value at least 1.6-fold (0.21 log units) away from the limit.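

In this assay compound 3 reads > 32500 nM, which is a limit of the assay and not a number. From the compounds shown here alone, replacing (3,4-dichlorophenyl)amino with 4-chloro-3-(trifluoromethyl)phenyl on the carbonyl carbon turns the urea into an amide and gives an at least 1.1-fold higher number from compound 1 to compound 3 (0.07 log units; that floor lies within the scatter), so this first change at this place brings no sign of stronger inhibition of growth, while its true size stays unknown. The reading for this change ends at the edge of what the assay reports: the limit of > 32500 nM in this assay, at which 1 of the 3 values shown sits.

This one change removes the amide-type nitrogen with its hydrogen and also alters the groups on the aromatic ring, so the compounds shown cannot separate these two parts. They also leave open how a simple amine or a morpholine on the carbonyl carbon would read.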